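The compounds below may be only part of what the source reports. "The series", "measured", "known", "first", "only" and "open" are said of these compounds alone.

Series notes. All four compounds share the same urea core carrying a cycloheptyl group and a trimethylphenyl group, and differ only in the aromatic ring attached to the benzylic arm. Compound 1 `Cc1cc(C)c(NC(=O)N(Cc2cc(-c3ccccc3)on2)C2CCCCCC2)c(C)c1` in an assay on microsomes from intestine for inhibition of acyl-CoA:cholesterol acyltransferase (Oryctolagus cuniculus) (on this read-out higher numbers stand for weaker inhibition and lower numbers for stronger inhibition), gives 61 nM. Compound 3 `Cc1cc(C)c(NC(=O)N(Cc2ccc(-c3ccsc3)cc2)C2CCCCCC2)c(C)c1` gives 19 nM in this assay. Compound 2 `Cc1cc(C)c(NC(=O)N(Cc2cccc(-c3nn[nH]n3)c2)C2CCCCCC2)c(C)c1` gives > 1000 nM, which is a limit of the assay and not a number (the limit of > 1000 nM in this assay, at which 1 of the 3 values shown sits). So compound 2 stands at the weak end of the three values shown, while compound 1 and compound 3 both fall well inside the measurable range.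

Compound 4 `Cc1cc(C)c(NC(=O)N(Cc2cccc(-n3cccc3)c2)C2CCCCCC2)c(C)c1` is not yet measured. Its change from compound 2 is 1H-pyrrol-1-yl in place of 2H-tetrazol-5-yl on an aromatic carbon. Within the data shown here, no step between measured compounds covers this pair, so the size of the step can only be expected, not read off. The expectation is for a clear gain in this assay, with the value of compound 4 moving away from the weak end where compound 2 sits. Among the measured compounds shown here, the range toward which it is expected to move is the one in which compound 1 gives 61 nM and compound 3 gives 19 nM. On that basis compound 4 is estimated at 60 nM, with a range from 15 nM to 300 nM. The step this implies from compound 2 to compound 4 is estimated as an at least 16-fold lower number from compound 2 to compound 4 (1.22 log units; beyond the scatter), beyond the scatter.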

Compound 4, half-maximal inhibitory concentration: 20 nM
For compound 4 the middle estimate is 3.0-fold (0.48 log units) above the measured one, and the stated range covers the measured number.
By their numbers in this assay, from the lowest: compounds 3 and 4 (each within the scatter of the next); then compound 1. At a limit, above all of these: compound 2.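

Exchanging 2H-tetrazol-5-yl for 1H-pyrrol-1-yl on this aromatic carbon, meta to a large group, gives an at least 50-fold lower number from compound 2 to compound 4 (1.69 log units; beyond the scatter) in this assay, so this place on the ring can carry a group with strong inhibition. Both groups are five-membered aromatic rings with the same number of heavy atoms, so ring size and heavy-atom count do not separate the pair; what differs is the number of hetero atoms, hydrogen-bond donors and hydrogen-bond acceptors. Compound 2 gives a limit of the assay and not a number: the limit of > 1000 nM in this assay, at which 1 of the 4 values shown sits.

This single pair cannot show whether the hydrogen-bond donor or the ring nitrogens matter more, as they change together from compound 2 to compound 4. Also open, from the compounds shown here alone, is how this assay responds at the same place to a carboxylic acid, a primary amine or a simple phenyl ring, any of which would show whether the result for compound 2 extends beyond 2H-tetrazol-5-yl.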